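A few compounds are considered here, and "the series" means these few. Any claim that something is new, unique, unknown or untested is made for them only; others in the source may bear on it.

Measured so far: compound 1 `Cc1c(C(=O)O)c(-c2cccc(N3CCN(c4ccc(NS(=O)(=O)c5ccc(N[C@H](CCN6CC(O)C6)CSc6ccccc6)c(S(=O)(=O)C(F)(F)F)c5)cc4)CC3)c2)c(-c2ccc(Cl)cc2)n1C`, 299 nM; compound 2 `CCCCn1c(C)c(C(=O)O)c(-c2cccc(N3CCN(c4ccc(NS(=O)(=O)c5ccc(N[C@H](CCN6CCC(O)CC6)CSc6ccccc6)c(S(=O)(=O)C(F)(F)F)c5)cc4)CC3)c2)c1-c1ccc(Cl)cc1`, 97 nM; compound 3 `Cc1c(C(=O)O)c(-c2cccc(N3CCN(c4ccc(NS(=O)(=O)c5ccc(N[C@H](CCN6CCC(O)CC6)CSc6ccccc6)c(S(=O)(=O)C(F)(F)F)c5)cc4)CC3)c2)c(-c2ccc(Cl)cc2)n1C(C)C`, 9 nM.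

In a functional assay on NCI-H1417 cells (Homo sapiens) for inhibition, read by WST assay, with a stated time of 4 days (a lower number here means a stronger inhibitor, a higher number a weaker inhibitor), compound 1 gives the highest number of the three, with compound 2 nearest to it and compound 3 furthest away, both gaps beyond the scatter. Compound 4 `Cc1c(C(=O)O)c(-c2cccc(N3CCN(c4ccc(NS(=O)(=O)c5ccc(N[C@H](CCN6CCCC6)CSc6ccccc6)c(S(=O)(=O)C(F)(F)F)c5)cc4)CC3)c2)c(-c2ccc(Cl)cc2)n1C` has not yet been measured. It differs from compound 1 in one place: pyrrolidin-1-yl in place of 3-hydroxyazetidin-1-yl on a saturated chain carbon, three bonds along the chain from a nitrogen on an aromatic ring. For the measured compounds named here, no measured pair shows this particular change, so nothing among the measured compounds sets its size. The step is expected to be small, in either direction or none beyond the scatter. The estimate for compound 4 implies a 1.2-fold lower number from compound 1 to compound 4 (0.08 log units; within the scatter). Compound 4 is therefore expected to give about 250 nM in this assay, within a range from 80 nM to 800 nM.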

Compound 4, half-maximal inhibitory concentration: 106 nM
The estimate for compound 4 lay 2.4-fold (0.37 log units) above the measured number; the range from low to high includes it.
By their numbers in this assay, from the lowest: compound 3; then compounds 2 and 4 (each within the scatter of the next); then compound 1.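

In this assay, the group on a saturated chain carbon, three bonds along the chain from a nitrogen on an aromatic ring, proves able to shift the number: pyrrolidin-1-yl in place of 3-hydroxyazetidin-1-yl gives a 2.8-fold lower number from compound 1 to compound 4 (0.45 log units; beyond the scatter). This single change enlarges the ring and removes the hydroxyl together, so the two cannot be told apart. Nothing available explains the step.

On these data alone, it remains open which of the two carries the step. Azetidin-1-yl and 3-hydroxypyrrolidin-1-yl at this place would separate them.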